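Trimming the amine terminus: from compound 2 to compound 3

A few compounds are considered here, and "the series" means these few. Any claim that something is new, unique, unknown or untested is made for them only; others in the source may bear on it.

Two members of the series carry a measurement in an assay on cells for inhibition of Voltage-dependent T-type calcium channel subunit alpha-1H (Homo sapiens), read by FLIPR and calcium flux, with stated times of 600 s and 300 s; on this read-out lower numbers stand for stronger inhibition and higher numbers for weaker inhibition. Compound 1 `CN(Cc1ccc(OCCCN)cc1)c1nc2ccc(Oc3ccc(C(F)(F)F)cc3)cc2s1` gives 248000 nM in this assay. Compound 2 `CN(Cc1ccc(OCCCNC(=N)N)cc1)c1nc2ccc(Oc3ccc(F)cc3)cc2s1` gives 521000 nM in this assay, the highest of the two numbers; its nearest neighbour is compound 1, which sits beyond the scatter with the lower number. Compound 1 and compound 2 differ in two places at once, so no single step can be read from them.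

Compound 3 `CN(Cc1ccc(OCCCN)cc1)c1nc2ccc(Oc3ccc(F)cc3)cc2s1` has not been measured in this assay. It differs from compound 2 by a hydrogen atom in place of a group of 3 heavy atoms (1 carbon, 2 nitrogen; no ring), on an amine nitrogen. The aryl ether of compound 2 is kept.

Within the data shown here, no measured pair isolates this change. Among the measured compounds shown here, the only guide is the other compound bearing the free amine: in this assay compound 1 gives 248000 nM, the lower of the two numbers. A modest downward step is therefore expected, a 1.6-fold lower number from compound 2 to compound 3 (0.21 log units; within the scatter), though the gap between compound 1 and compound 2 cannot be split between the two places where they differ. Compound 3 is estimated at 320000 nM in this assay, within a range of 130000 nM to 800000 nM.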

Compound 3, half-maximal inhibitory concentration: 492000 nM
Compound 3: middle estimate off by 1.5-fold (0.19 log units), on the low side; measured number inside the range.
By their numbers in this assay, from the lowest: compounds 1, 3 and 2 (each within the scatter of the next, the first and the last beyond it).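

Replacing the group of 3 heavy atoms (1 carbon, 2 nitrogen; no ring) on the amine nitrogen with a hydrogen atom gives a 1.1-fold lower number from compound 2 to compound 3 (0.02 log units; within the scatter) in this assay, so this read-out does not separate the free amine from its substituted form at this position. Fluoro in place of trifluoromethyl on an aromatic carbon, the other place in which compound 1 and compound 2 differ, can now also be read alone as a 2.0-fold higher number from compound 1 to compound 3 (0.30 log units; within the scatter), so this change too stays inside the usual scatter, though at its edge. No measurement at hand speaks to the origin of either step.

On these data alone, whether a carboxylic acid or an amide in place of the amine, or a longer chain carrying it, would move the number beyond the scatter remains open. Also open, as far as these compounds go, is whether a chloro or nitrile group on the aromatic carbon that holds fluoro in compound 3 would give a number distinct from those of compound 1 and compound 3.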